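The source may report more compounds than this note shows. Statements on the series, on what has been measured and on what is new or still open speak of the compounds shown alone.

Measured in a functional assay on U-87MG ATCC cells (Homo sapiens) for antiproliferative activity; a lower number here means a stronger inhibitor, a higher number a weaker inhibitor:
- compound 1 `Cc1c2c(n3c1CCNC[C@@H](C)[C@H](C)Nc1cc-3ccc1C(N)=O)CC(C)(C)CC2=O`: 40 nM
- compound 2 `CC(=O)N1CCc2c(C)c3c(n2-c2ccc(C(N)=O)c(c2)N[C@@H](C)[C@H](C)C1)CC(C)(C)CC3=O`: 24 nM
- compound 3 `COCCC(=O)N1CCc2c(C)c3c(n2-c2ccc(C(N)=O)c(c2)N[C@@H](C)[C@H](C)C1)CC(C)(C)CC3=O`: 54 nM

Among the measured compounds shown here, compound 3 stands clear of only one other compound. The data show a 2.3-fold higher number from compound 2 to compound 3 (0.35 log units; beyond the scatter), but also a 1.4-fold higher number from compound 1 to compound 3 (0.13 log units; within the scatter).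

Compound 4 `CC[C@H](N)C(=O)N1CCc2c(C)c3c(n2-c2ccc(C(N)=O)c(c2)N[C@@H](C)[C@H](C)C1)CC(C)(C)CC3=O` keeps the shared core, with 1-aminopropyl in place of 2-methoxyethyl on a carbonyl carbon. For the measured compounds named here, no measured step introduces an amine-bearing chain. The nearest guides are the other changes at this carbonyl group, above all a 1.7-fold lower number from compound 1 to compound 2 (0.22 log units; within the scatter), alongside the modest step already shown between compound 2 and compound 3. These steps are small and give no direction for the new group, so no change beyond the scatter is expected in this assay. The expected step is a 1.2-fold lower number from compound 3 to compound 4 (0.08 log units; within the scatter). For compound 4 the estimated value is 45 nM, with an expected range of 15 nM to 130 nM.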

Compound 4, half-maximal inhibitory concentration: 45 nM
For compound 4 middle estimate and measured number coincide at the digits printed, within the range that was stated.
By their numbers in this assay, from the lowest: compounds 2, 1, 4 and 3 (each within the scatter of the next, the first and the last beyond it).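

In this assay, 1-aminopropyl in place of 2-methoxyethyl on the carbonyl carbon gives a 1.2-fold lower number from compound 3 to compound 4 (0.08 log units; within the scatter), so a chain carrying an amine and a defined stereocentre fits here about as well as the ether chain. Read against the smaller neighbours, the same group gives a 1.9-fold higher number from compound 2 to compound 4 (0.27 log units; within the scatter) and a 1.1-fold higher number from compound 1 to compound 4 (0.05 log units; within the scatter), so compound 4 stands clear of none of the other three compounds. Nothing measured here bears on why these steps are so small.

The compounds shown leave open how the mirror-image 1-aminopropyl group, a longer amine chain or a carboxylic acid on this carbonyl carbon would behave. Going by these compounds, whether any such group moves the number beyond the scatter also remains open.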